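The compounds below may be only part of what the source reports. "The series", "measured", "known", "first", "only" and "open" are said of these compounds alone.

Notes on the series in a functional assay on COLO 205 cells (Homo sapiens) for inhibition, read by MTT assay, with a stated time of 24 h; a higher number here means a weaker inhibitor, a lower number a stronger inhibitor. Compound 1 `C/C=C(\C)C(=O)O[C@H]1[C@]2(C)C[C@@H]3O[C@@]1(O)C=C1C4=CC(=O)O[C@@H](c5ccoc5)[C@]4(C)CC[C@@H]1[C@]3(C)[C@@H]2C(=O)C(=O)OC` gives > 100000 nM, which is a limit of the assay and not a number. Compound 2 `C/C=C(\C)C(=O)O[C@@H]1[C@]2(OC(=O)CCCC)C=C3C4=CC(=O)O[C@@H](c5ccoc5)[C@]4(C)CC[C@@H]3[C@@]3(C)[C@H](C[C@]1(C)[C@H]3[C@@H](OC(=O)CCCC)C(=O)OC)O2` gives > 100000 nM, again a limit. For the measured compounds named here, compound 3 `C/C=C(\C)C(=O)O[C@@H]1[C@]2(OC(=O)CCCC)C=C3C4=CC(=O)O[C@@H](c5ccoc5)[C@]4(C)CC[C@@H]3[C@@]3(C)[C@H](C[C@]1(C)[C@H]3[C@@H](O)C(=O)OC)O2` reads 4000 nM, the only actual number so far, so it is the sole numerical reference point for what follows.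

The next change leads to compound 4 `C/C=C(\C)C(=O)O[C@@H]1[C@]2(OC(=O)C3CC3)C=C3C4=CC(=O)O[C@@H](c5ccoc5)[C@]4(C)CC[C@@H]3[C@@]3(C)[C@H](C[C@]1(C)[C@H]3[C@@H](O)C(=O)OC)O2`: cyclopropyl in place of butyl on a carbonyl carbon, or butylcarbonyl to cyclopropylcarbonyl.

Going by the values given here, one measured step bears on this, and only indirectly: an at least 25-fold lower number from compound 2 to compound 3 (1.39 log units; beyond the scatter), with hydrogen in place of butylcarbonyl on an oxygen on a saturated carbon. That step is large, but it removes a whole group at a different place. Among the compounds with values here, the butylcarbonyl exchanged in compound 4 stays untouched through it, so no measured step gives a direction for the present swap. The group is replaced rather than removed, so a much smaller shift is expected, although the size of an at least 25-fold lower number from compound 2 to compound 3 (1.39 log units; beyond the scatter) argues for a wide range.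

In this assay the expected step is no change at the digits printed from compound 3 to compound 4 (within the scatter), with nothing beyond the scatter anticipated in either direction. For compound 4 the estimated value is 4000 nM, with an expected range of 1200 nM to 20000 nM.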

Compound 4, half-maximal inhibitory concentration: > 100000 nM
Compound 4: only a limit was reported; the forecaster's own chance of this, stated with the estimate: 15%; middle value at least 25-fold (1.39 log units) from the limit.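

In this assay, replacing butyl with cyclopropyl on a carbonyl carbon gives an at least 25-fold higher number from compound 3 to compound 4 (1.39 log units; beyond the scatter), so this position is not indifferent to the group it carries, even though the swap leaves the shared core and the rest of the molecule unchanged. For the compounds shown here, this is the first measured step at this position, as the earlier step concerned a different oxygen and left the butylcarbonyl in place. Any size read from the step is only a bound, and the series offers little numerical resolution: the limit of > 100000 nM in this assay, at which 3 of the 4 values shown sit.

Going by these compounds, it remains open whether the change in compound 4 is specific to cyclopropyl or would also follow from other replacements for butyl, and a straight propyl chain, a longer chain such as hexyl, or a chain ending in an amine would help separate these readings. Going by these compounds alone, also open is whether butyl and the free hydroxyl group of compound 3 act independently, as each change appears here only singly and compound 3 is the sole compound with a number.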